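This account rests on a few compounds, and the source may have more. Where it says the series, first, only, none or still open, it means among the compounds named here.

Compound 2 `COc1cc(-n2cnc3ccc(-c4ccccc4Cl)cc32)cc(OC)c1OC` reaches only the limit of this assay, > 10000 nM, which is a boundary of the measurement rather than a number. In a functional assay on MCF7 cells (Homo sapiens) for antiproliferative activity, read by MTT assay, with a stated time of 72 h (on this read-out higher numbers stand for weaker inhibition and lower numbers for stronger inhibition), compound 1 `CCOc1ccc(-c2ccc3ncn(-c4cc(OC)c(OC)c(OC)c4)c3c2)cc1` gives 1710 nM, and compound 3 `COc1cc(-n2cnc3ccc(-c4ccc(Cl)cc4)cc32)cc(OC)c1OC` gives 1320 nM. The step of an at least 5.8-fold higher number from compound 1 to compound 2 (0.76 log units; beyond the scatter) and the step of an at least 7.5-fold lower number from compound 2 to compound 3 (0.87 log units; beyond the scatter) both show that the compound carrying the 2-chlorophenyl group sits at the weak end of this small set, while the two with a 4-ethoxyphenyl or a 4-chlorophenyl group give numbers close to one another a 1.3-fold lower number from compound 1 to compound 3 (0.11 log units; within the scatter). Compound 4 `COc1cccc(-c2ccc3ncn(-c4cc(OC)c(OC)c(OC)c4)c3c2)c1` differs from compound 2 in the same part of the molecule: 3-methoxyphenyl in place of 2-chlorophenyl on an aromatic carbon. Among the measured compounds shown here, no measured compound carries a 3-methoxyphenyl group, so the size of the step is uncertain. Since both measured changes away from the 2-chlorophenyl group gave at least modest lower numbers, a lower number is expected for compound 4 as well, by an estimated step of an at least 3.3-fold lower number from compound 2 to compound 4 (0.52 log units; beyond the scatter). Compound 4 is therefore expected to give about 3000 nM in this assay, within a range from 1000 nM to 10000 nM.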

Compound 4, half-maximal inhibitory concentration: 1610 nM
For compound 4 the middle estimate is 1.9-fold (0.27 log units) above the measured one, and the stated range covers the measured number.
By their numbers in this assay, from the lowest: compounds 3, 4 and 1 (each within the scatter of the next). At a limit, above all of these: compound 2.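

The step to the 3-methoxyphenyl group is an at least 6.2-fold lower number from compound 2 to compound 4 (0.79 log units; beyond the scatter), so compound 2 now stands apart from three differently substituted phenyl compounds rather than two. Set against the other two, compound 4 shows no separation, with a 1.2-fold higher number from compound 3 to compound 4 (0.09 log units; within the scatter) and a 1.1-fold lower number from compound 1 to compound 4 (0.03 log units; within the scatter): at this position, 3-methoxyphenyl, 4-chlorophenyl and 4-ethoxyphenyl cannot be told apart, even though the 3-methoxyphenyl group carries its substituent at a different ring position from the other two. The value of compound 2 remains a limit and not a number: the limit of > 10000 nM in this assay, at which 1 of the 4 values shown sits.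

Still open, on these data alone, is whether the weak result of compound 2 depends on the chlorine, on its place on the ring, or on both, which a 2-methoxyphenyl or a 3-chlorophenyl group could help to separate. As far as these compounds go, how a phenyl ring bearing an amine or a carboxylic acid would behave at this position also remains open.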